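This account rests on a few compounds, and the source may have more. Where it says the series, first, only, none or still open, it means among the compounds named here.

Measured in a functional assay on KB cells (Homo sapiens) for inhibition, with a stated time of 72 h; on this read-out lower numbers stand for stronger inhibition and higher numbers for weaker inhibition:
- Compound 1 `COc1ccc(S(=O)(=O)N2CCc3cccc(-c4ccc(O)cc4)c32)cc1`: 129 nM
- Compound 2 `COc1ccc(S(=O)(=O)N2CCc3cccc(-c4ccc(C#N)cc4)c32)cc1`: 31.1 nM

Compound 2 has the lower of the two numbers. Compound 3 `COc1ccc(S(=O)(=O)N2CCc3cccc(-c4cccs4)c32)cc1` departs from it by thiophen-2-yl in place of 4-cyanophenyl on an aromatic carbon, with thiophen-2-yl in place of 4-cyanophenyl on an aromatic carbon. Within the data shown here, only one measured step bears on this, a 4.1-fold lower number from compound 1 to compound 2 (0.62 log units; beyond the scatter), which is modest and swaps a group on the aromatic substituent without replacing that substituent. It therefore gives only a rough guide to size. Among the measured compounds shown here, a modest step to a higher number is expected in this assay, though no measured step tests this direction. The expected change is a 1.9-fold higher number from compound 2 to compound 3 (0.29 log units; within the scatter). For compound 3 the estimated value is 60 nM, with an expected range of 20 nM to 180 nM.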

Compound 3, half-maximal inhibitory concentration: 215 nM
For compound 3 the middle estimate is 3.6-fold (0.55 log units) below the measured one, and the stated range ends below it.
By their numbers in this assay, from the lowest: compound 2; then compounds 1 and 3 (each within the scatter of the next).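

In this assay the whole aryl group on this aromatic carbon can be exchanged, not only its substituent: thiophen-2-yl in place of 4-cyanophenyl gives a 6.9-fold higher number from compound 2 to compound 3 (0.84 log units; beyond the scatter) and gives up the advantage of compound 2. Against the hydroxy analogue, the same ring gives a 1.7-fold higher number from compound 1 to compound 3 (0.22 log units; within the scatter), so thiophen-2-yl and 4-hydroxyphenyl are not separated here. No available evidence explains these differences.

As far as these compounds go, whether the low number of compound 2 rests on the nitrile or on the phenyl ring carrying it stays open. From the compounds shown here alone, how a phenyl ring carrying an amine or a carboxylic acid would read at this carbon is also open.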